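A few compounds are considered here, and "the series" means these few. Any claim that something is new, unique, unknown or untested is made for them only; others in the source may bear on it.

Measured compounds:
compound 1 `COc1ccc(C2N=C(SCc3ccccc3)NC(C)=C2C(=O)Nc2ccc(F)cc2)cc1OC` gives 6.2%
compound 2 `COc1ccc(C2N=C(SCc3cccc(Cl)c3)NC(C)=C2C(=O)Nc2ccc(F)cc2)cc1OC` gives 8.2%
compound 3 `COc1ccc(C2N=C(SCc3ccc(F)cc3)NC(C)=C2C(=O)Nc2ccc(F)cc2)cc1OC` gives 11.8%

These three values come from a functional assay on the whole organism (artery, strain albino) with Rattus norvegicus as the target, with a stated time of 60 min, at a dose of 10 mg/kg by the oral route; a higher number here means more inhibition at the dose given (going by the name of the read-out), a lower number less inhibition. On the numbers shown, compound 1 has the lowest of the three, but its nearest neighbour is compound 2, with a number 2 percentage points higher from compound 1 to compound 2 (within the scatter), and its furthest is compound 3, with a number 5.6 percentage points higher from compound 1 to compound 3 (within the scatter); both steps lie within the scatter, so no order among the three can be claimed. The step of a number 3.6 percentage points higher from compound 2 to compound 3 (within the scatter) is likewise within the scatter.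

Compound 4 `CC1=C(C(=O)Nc2ccc(F)cc2)C(c2ccc([N+](=O)[O-])cc2)N=C(SCc2ccccc2)N1` has not yet been measured in this assay. It differs from compound 1 in one place: 4-nitrophenyl in place of 3,4-dimethoxyphenyl on a saturated ring carbon. For the measured compounds named here, none of the measured steps touches that saturated ring carbon; every one of them changes the aryl group bound through the sulfur, and each stayed within the scatter. Nothing in the shown data therefore points to a step beyond the scatter for compound 4, and the expected change is a number 1.8 percentage points higher from compound 1 to compound 4 (within the scatter). Compound 4 is estimated to give 8%, with a range from 0% to 20%.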

Compound 4, a percentage reported as inhibition, in the whole organism at one dose (the size of the read-out at that dose, not a potency): 12.3%
Compound 4: the middle estimate sits 4.3 percentage points below what was measured, within the range that was stated.
By their numbers in this assay, from the lowest: compounds 1, 2, 3 and 4 (each within the scatter of the next).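

In this assay, the change at the saturated ring carbon, 4-nitrophenyl in place of 3,4-dimethoxyphenyl, gives a number 6.1 percentage points higher from compound 1 to compound 4 (within the scatter). The step therefore extends the picture beyond the aryl group on the sulfur side: even an exchange of both methoxy groups for a nitro group at this other position, on the same aromatic ring of carbon only, does not carry the number beyond the scatter. No measurement shown accounts for this result, so nothing can be said about its cause.

For the compounds shown here, whether this saturated ring carbon can shift the number beyond the scatter at all remains open, since it is represented by only this one exchange. An amine or a carboxylic acid on the aromatic ring, or a longer chain in place of that ring, might behave differently, and the compounds shown cannot settle that.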